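This account rests on a few compounds, and the source may have more. Where it says the series, first, only, none or still open, it means among the compounds named here.

Working notes on the series. The shared core is that of compound 1 `O=C1NC(=O)C2(CSC3=C2C(=O)c2ncccc2C3=O)N1`, which carries no substituent beyond the core itself. Compound 2 `O=C1C2=C(C(=O)c3ncccc31)C1(CS2)NC(=O)N(c2ccccc2)C1=O` is the phenyl-bearing analogue. In a functional assay on HT-29 cells (Homo sapiens) for antiproliferative activity, read by MTT assay, with a stated time of 96 h (a lower number here means a stronger inhibitor, a higher number a weaker inhibitor), compound 1 gives 190 nM; 180 nM; 190 nM (3 entries), with the repeats agreeing closely (the several entries of compound 1 in this assay, 190 nM; 180 nM; 190 nM (3 entries)), while compound 2 in this assay gives 2 nM. For the measured compounds named here, no step between the two is worked out here; the two numbers simply stand as they are, the phenyl analogue at the lower figure. For compound 2 this is the only number shown; one further entry for it gives no single number, so its position rests on a single value.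

Compound 3 `CCc1ccc(N2C(=O)NC3(CSC4=C3C(=O)c3ncccc3C4=O)C2=O)cc1` is the next member: the change from compound 2 is ethyl in place of hydrogen on an aromatic carbon. No measured step exists for a change of this kind in the series, so the size of the step in this assay cannot be read off from the data. The expectation is that the step from compound 2 to compound 3, estimated as a 1.5-fold higher number from compound 2 to compound 3 (0.18 log units; within the scatter), stays within the usual scatter or amounts to a modest loss. Compound 3 is therefore expected to give about 3 nM, with a range from 0.8 nM to 12 nM.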

Compound 3, half-maximal inhibitory concentration: 1 nM
Beside the measured number, compound 3's estimate is 3.0-fold (0.48 log units) above it; the measured number falls inside the stated range.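

In this assay, the change from phenyl to 4-ethylphenyl, with ethyl on an aromatic carbon para to a large group, gives a 2.0-fold lower number from compound 2 to compound 3 (0.30 log units; within the scatter), so this position takes ethyl without a step beyond the scatter. For the compounds shown here, the earlier compounds offered no step at this place, and the single figure for compound 2 now has a second compound with one change beside it, so the value no longer describes only the unsubstituted phenyl. Nothing in the data shown accounts for the size of this step.

What remains open is whether the same position also accepts an amine, a carboxylic acid or a longer chain such as butyl, since ethyl is the only group shown there and a single step says nothing about how far the tolerance extends. Also open, going by these compounds, is whether ethyl on another aromatic carbon of the same ring would give a comparable number in this assay.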